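Swapping the acetoxyethyl arm of compound 1 for a cyclic ester

The source may hold more compounds than are shown below. What is called first, only, known or untested is meant among the compounds shown, and "the series" means these compounds.

The three measured compounds share one core and differ only in the group carried on the oxygen of the side chain. Compound 1 `CC(=O)OCCO[C@H](CC=C(C)C)C1=CC(=O)c2c(O)ccc(O)c2C1=O` gives 15500 nM in a functional assay on DU-145 cells (Homo sapiens) for cytotoxicity, read by MTT assay (a lower number here means a stronger inhibitor, a higher number a weaker inhibitor), the lowest of the three numbers. Compound 3 `CCC(CO[C@H](CC=C(C)C)C1=CC(=O)c2c(O)ccc(O)c2C1=O)OC(C)=O` gives 25400 nM in this assay, and the step of a 1.6-fold higher number from compound 1 to compound 3 (0.21 log units; within the scatter) shows that adding an ethyl there changes little. Within the data shown here, compound 2 `CCCC(CC(=O)O[C@H](CC=C(C)C)C1=CC(=O)c2c(O)ccc(O)c2C1=O)OC(C)=O` gives 55700 nM in this assay; its gap to compound 1 lies beyond the scatter, but the two structures differ in more than one place, so no single step can be drawn from the pair.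

Compound 4 `CC(C)=CC[C@@H](OC(=O)C1CCCO1)C1=CC(=O)c2c(O)ccc(O)c2C1=O` is not yet measured. It differs from compound 1 by (oxolan-2-yl)carbonyl in place of 2-acetoxyethyl on an oxygen on a saturated carbon. Among the measured compounds shown here, no measured step covers this change directly. For the measured compounds named here, the only single-place step, from compound 1 to compound 3, stayed within the scatter, while compound 2, the one measured compound carrying a carbonyl on that oxygen, gave the highest number. Compound 4 is therefore expected to land somewhat above compound 1, with the step of a 1.4-fold higher number from compound 1 to compound 4 (0.15 log units; within the scatter) small and possibly within the scatter. The estimate for compound 4 in this assay is 22000 nM, with a range from 8000 nM to 60000 nM.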

Compound 4, half-maximal inhibitory concentration: 10500 nM
Estimate against measurement, compound 4: 2.1-fold (0.32 log units) above; the range from low to high includes it.
By their numbers in this assay, from the lowest: compounds 4, 1 and 3 (each within the scatter of the next, the first and the last beyond it); then compound 2.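

In this assay, among these compounds, the step of a 1.5-fold lower number from compound 1 to compound 4 (0.17 log units; within the scatter) stays within the scatter, so (oxolan-2-yl)carbonyl on this oxygen, the first group here with a five-membered non-aromatic ring, does about as well as 2-acetoxyethyl. Among the compounds shown here, a carbonyl on this oxygen had so far appeared only in compound 2, with the highest number of the series, but the step of a 5.3-fold lower number from compound 2 to compound 4 (0.72 log units; beyond the scatter) lies beyond the scatter with that carbonyl kept, which ties the high number of compound 2 to its 2-acetoxypentyl group and not to the carbonyl alone. For the compounds shown here, the step of a 2.4-fold lower number from compound 3 to compound 4 (0.38 log units; beyond the scatter) also lies beyond the scatter, a modest gap that the earlier compounds could not show, so the group in compound 4 sits clearly apart from 2-acetoxybutyl at this position.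

No measurement in hand gives a reason for any of these steps. As far as these compounds go, it remains open whether the ring or its oxygen matters at all, which an open-chain butanoyl group, a cyclopentanecarbonyl group or a pyrrolidine-2-carbonyl group on the same oxygen would test.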